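Series notes: methoxy replacing iodo, compound 3 to compound 4

The source may report more compounds than this note shows. Statements on the series, on what has been measured and on what is new or still open speak of the compounds shown alone.

The shared core of compound 1 `CCNC/C=C(/c1ccc(Br)cc1)c1cccnc1` carries an amine at the end of a short chain. In an in vivo functional assay on the whole organism (brain) for inhibition of Norepinephrine transporter (Rattus norvegicus) (on this read-out higher numbers stand for an effect only at larger amounts of compound and lower numbers for an effect already at smaller amounts), compound 1 gives > 102 umol/kg, which is a limit of the assay and not a number. Compound 2 `CCCNC/C=C(/c1ccc(Br)cc1)c1cccnc1` in this assay gives > 95 umol/kg, again a limit. Between these two, a step that the two limits leave unreadable from compound 1 to compound 2 cannot be read. Compound 3 `CN(C)C/C=C(/c1ccc(I)cc1)c1cccnc1` in this assay gives > 88 umol/kg, also a limit; compound 3 thus sits among three values that are all limits (the limit of > 102 umol/kg in this assay, at which 1 of the 3 values shown sits, (the limit of > 88 umol/kg in this assay, at which 1 of the 3 values shown sits), (the limit of > 95 umol/kg in this assay, at which 1 of the 3 values shown sits)). Compound 4 `COc1ccc(/C(=C/CN(C)C)c2cccnc2)cc1` differs from compound 3 by methoxy in place of iodo on an aromatic carbon. For the measured compounds named here, no measured step bears on this change, and no step is readable. The expectation is therefore no readable shift, a step that the limit leaves unreadable from compound 3 to compound 4, so compound 4 is expected to give 150 umol/kg in this assay, within 40 umol/kg to 500 umol/kg, most likely once more as a limit.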

Compound 4, dose for half-maximal effect: > 112 umol/kg
Compound 4 was reported as a limit; the forecaster's own chance of this, stated with the estimate: 70%; the middle value is on the limit's open side.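

In this assay compound 4 gives > 112 umol/kg, a limit and not a number. For the compounds shown here, compound 3 also stands as a limit, so no step between compound 3 and compound 4 can be read. The compounds shown leave open whether methoxy in place of iodo shifts the dose for half-maximal effect.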